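The source may hold more compounds than are shown below. What is called first, only, known or untested is meant among the compounds shown, and "the series" means these compounds.

Compound 1 `CC1(C)N=C(N)N=C(N)N1c1ccccc1S` gives 7.69 in an assay for inhibition of Dihydrofolate reductase (Bos taurus), at pH 7.20; a lower number here means a less potent compound, a higher number a more potent compound, by a factor of ten per unit of this negative logarithm. Compound 2 `CCc1ccccc1N1C(N)=NC(N)=NC1(C)C` gives 4.48 in this assay, and compound 3 `CC1(C)N=C(N)N=C(N)N1c1ccccc1O` gives 4.18 in this assay. Among the three numbers compound 2 stands second highest; its nearest neighbour is compound 3, where the step of a number 0.30 log units lower from compound 2 to compound 3 (within the scatter) lies within the scatter, and its furthest is compound 1, where a number 3.21 log units lower from compound 1 to compound 2 (beyond the scatter) is large. Compound 4 `CC1(C)N=C(N)N=C(N)N1c1ccccc1C(F)(F)F` has not yet been measured in this assay; it differs from compound 2 as follows: trifluoromethyl in place of ethyl on an aromatic carbon. Among the compounds with values here, no measured step replaces ethyl by trifluoromethyl, so only indirect bearings exist. The step of a number 0.30 log units lower from compound 2 to compound 3 (within the scatter), which also exchanges the group on this aromatic carbon, stayed within the scatter, whereas a number 3.51 log units lower from compound 1 to compound 3 (beyond the scatter) and a number 3.21 log units lower from compound 1 to compound 2 (beyond the scatter) show that this position can move the number a great deal. For compound 4 a step near a number 0.12 log units higher from compound 2 to compound 4 (within the scatter) in this assay is expected, that is, nothing clearly beyond the scatter. Compound 4 is therefore estimated at 4.6 in this assay, between 3.8 and 5.6.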

Compound 4, logarithm of the reciprocal of the active concentration, log(1/C): 3.53
The estimate for compound 4 lay 1.07 log units above the measured number; measured number below the stated range.
By their numbers in this assay, from the lowest: compound 4; then compounds 3 and 2 (each within the scatter of the next); then compound 1.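

In this assay, the step of a number 0.95 log units lower from compound 2 to compound 4 (beyond the scatter) shows that this aromatic carbon can separate groups other than sulfanyl by more than the scatter, which the earlier exchange of ethyl for hydroxy did not show. With a number 0.65 log units lower from compound 3 to compound 4 (beyond the scatter) and a number 4.16 log units lower from compound 1 to compound 4 (beyond the scatter) also printed as beyond the scatter, trifluoromethyl gives the lowest number of the four compounds, and the range seen at this one position widens. No available measurement explains these differences.

The compounds shown leave open whether the high number of compound 1 is specific to sulfanyl, or whether a methylsulfanyl group or an amine on this carbon would come near it. They also leave open where a chlorine atom or a chain longer than ethyl would fall.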